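The source may hold more compounds than are shown below. What is called first, only, known or untested is meant among the compounds shown, and "the series" means these compounds.

Of the compounds shown here, two of this study have been tested so far. Compound 1 `C/C(=N\NC(=O)c1cc2ccccc2cc1O)c1ccc(N)cc1` and compound 2 `Cc1nn(-c2ncnc3nc[nH]c23)c2c1C(c1ccc(OC(C)C)cc1)CC(=O)N2` were both examined in a functional assay on HEK293 cells for agonist activity at G-protein coupled receptor 39 (Homo sapiens), read by scintillation proximity assay and inositol phosphate accumulation, with a stated time of 75 min, in the presence of a further agent that is not named here; on this read-out lower numbers stand for an effect already at smaller amounts and higher numbers for an effect only at larger amounts of compound. In this assay compound 1 gives 1100 nM. In this assay compound 2 gives 18 nM, the lower of the two numbers; the gap between compound 1 and compound 2 is wide and lies well beyond the usual scatter of repeated runs. Going by the values given here, no pair of measured compounds differs in a single place, so no single structural step has yet been measured.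

The account now turns to compound 3 `Cc1nn(-c2ncnc3nc[nH]c23)c2c1C(OCc1ccccc1Cl)CC(=O)N2`, which has not yet been tested in this assay. It is derived from compound 2 by one change: (2-chlorobenzyl)oxy in place of 4-isopropoxyphenyl on a saturated ring carbon. Among the compounds with values here, nothing among the measured compounds shows how a (2-chlorobenzyl)oxy group compares with a 4-isopropoxyphenyl group at this saturated ring carbon, so the expectation rests on the size of the change alone. A moderate loss is expected, so that the step from compound 2 to compound 3 is estimated at a 3.3-fold higher number from compound 2 to compound 3 (0.52 log units; beyond the scatter) in this assay. Compound 3 is therefore expected to give about 60 nM in this assay, with a plausible range from 15 nM to 300 nM.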

Compound 3, half-maximal effective concentration: 2 nM
Beside the measured number, compound 3's estimate is 30-fold (1.48 log units) above it; the measured number lies below the stated range.
By their numbers in this assay, from the lowest: compound 3; then compound 2; then compound 1.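

At this saturated ring carbon, three ring bonds from the ring nitrogen, the 4-isopropoxyphenyl group can be replaced without loss: in this assay, the (2-chlorobenzyl)oxy group gives a 9.0-fold lower number from compound 2 to compound 3 (0.95 log units; beyond the scatter), a step beyond the scatter. Both groups carry one six-membered aromatic ring of carbon only and one hydrogen-bond acceptor, with no hydrogen-bond donor and no net charge, so these counts do not separate them and the step has to be read against the different way the aromatic ring is joined to this carbon and the chlorine that enters with it. No measurement on hand bears on why the change runs in this direction.

The compounds shown leave open which part of the change carries the step, as the chlorine and the new oxygen link enter together, and a plain benzyloxy group would be needed to tell them apart. They also leave open how far this ring carbon accepts other kinds of group, such as an amine, a carboxylic acid or a longer alkoxy chain.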